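This account rests on a few compounds, and the source may have more. Where it says the series, first, only, none or still open, it means among the compounds named here.

Three compounds were measured in an assay on HEK293 cells for displacement of a labelled ligand from Melanocortin receptor 4 (Homo sapiens); a lower number here means a stronger inhibitor, a higher number a weaker inhibitor:

Compound 1 `CC(C)C[C@H](N)c1cc(C(F)(F)F)ccc1N1CCN(C(=O)CCc2cccc(C(F)(F)F)c2)CC1`: 2200 nM
Compound 2 `COc1ccc(CCC(=O)N2CCN(c3ccc(C(F)(F)F)cc3[C@@H](N)CC(C)C)CC2)cc1`: 350 nM
Compound 3 `CC(C)C[C@H](N)c1cc(C(F)(F)F)ccc1N1CCN(C(=O)CCc2cccs2)CC1`: 4600 nM

Compound 3 stands highest of the three numbers. Its nearest neighbour is reached by the step of a 2.1-fold higher number from compound 1 to compound 3 (0.32 log units; beyond the scatter), its furthest by the step of a 13-fold higher number from compound 2 to compound 3 (1.12 log units; beyond the scatter).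

Compound 4 `Cc1[nH]c2ccccc2c1CCC(=O)N1CCN(c2ccc(C(F)(F)F)cc2[C@@H](N)CC(C)C)CC1` is not yet measured. It differs from compound 3 in one place: 2-methyl-1H-indol-3-yl in place of thiophen-2-yl on a saturated chain carbon, two bonds along the chain from a carbonyl carbon. Every measured step changes the group at this same place: a 6.3-fold lower number from compound 1 to compound 2 (0.80 log units; beyond the scatter), a 2.1-fold higher number from compound 1 to compound 3 (0.32 log units; beyond the scatter) and a 13-fold higher number from compound 2 to compound 3 (1.12 log units; beyond the scatter). None of them involves the incoming group, so its direction rests only on compound 3 giving the highest number. A modest lower number is therefore expected for compound 4, namely a 3.8-fold lower number from compound 3 to compound 4 (0.58 log units; beyond the scatter). Compound 4 is estimated at 1200 nM, in the range 250 nM to 6000 nM.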

Compound 4, inhibition constant: 1600 nM
For compound 4 the middle estimate is 1.3-fold (0.12 log units) below the measured one; low and high end bracket the measured number.
By their numbers in this assay, from the lowest: compound 2; then compounds 4 and 1 (each within the scatter of the next); then compound 3.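

In this assay, at this place on the saturated chain, 2-methyl-1H-indol-3-yl gives a stronger result than thiophen-2-yl (a 2.9-fold lower number from compound 3 to compound 4 (0.46 log units; beyond the scatter)) but does not match 4-methoxyphenyl (a 4.6-fold higher number from compound 2 to compound 4 (0.66 log units; beyond the scatter)). Although it is the only group shown with a hydrogen-bond donor, it cannot be told apart from 3-(trifluoromethyl)phenyl (a 1.4-fold lower number from compound 1 to compound 4 (0.14 log units; within the scatter)). Nothing available accounts for these differences. The compounds shown leave open what the donor, the methyl or the six-membered ring each contributes. They also leave open how a carboxylic acid, an amine or a longer chain would fare at this place.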